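The source may hold more compounds than are shown below. What is called first, only, known or untested is meant among the compounds shown, and "the series" means these compounds.

Measured compounds so far:
Compound 1 `Fc1cccc(-c2n[nH]cc2N2CCCNCC2)c1`. In an assay on isolated protein for binding affinity to 5-hydroxytryptamine receptor 1E (Homo sapiens) (on this read-out lower numbers stand for stronger inhibition and higher numbers for weaker inhibition), compound 1 gives > 10000 nM, which is a limit of the assay and not a number.
Compound 2 `c1ccc(-c2n[nH]cc2N2CCCNCC2)cc1`. Compound 2 gives > 10000 nM, again a limit.
Compound 3 `COc1cccc(-c2n[nH]cc2N2CCNCC2)c1`. Compound 3 gives > 10000 nM, also a limit.

Among the measured compounds shown here, the one step with both ends measured, a step that the two limits leave unreadable from compound 1 to compound 2, cannot be read because of the limit of > 10000 nM in this assay, at which 3 of the 3 values shown sit. Compound 3 thus stands only at a limit, with nothing in the numbers to place it above or below the other two.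

Compound 4 `Fc1cccc(-c2n[nH]cc2N2CCNCC2)c1` differs from compound 3 in one place: fluoro in place of methoxy on an aromatic carbon. No readable measured step bears on this change; the step from compound 1 to compound 2 touches a fluoro group but gives no size. For the measured compounds named here, with three values all sitting at a limit and no step of known size, the expectation for compound 4 is that it also remains at the limit, with no step beyond the scatter, so the estimated step that the limit leaves unreadable from compound 3 to compound 4 is taken as none. For compound 4 the estimated value is 15000 nM, expected between 5000 nM and 50000 nM.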

Compound 4, inhibition constant: > 10000 nM
Compound 4: no number, only a limit (the forecaster's own chance of this, stated with the estimate: 85%); the middle value does not contradict the limit.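

No step can be read from compound 3 to compound 4 in this assay, because neither compound gives a number: the limit of > 10000 nM in this assay, at which 4 of the 4 values shown sit.

The compounds shown leave open whether fluoro in place of methoxy, or any other change on the shared core, alters binding in this assay.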